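Thiazol-2-yl amide variant of the benzisothiazolone acetamide series

The source may report more compounds than this note shows. Statements on the series, on what has been measured and on what is new or still open speak of the compounds shown alone.

Measured so far in an assay on isolated protein for inhibition of histone acetyltransferase KAT2B (Homo sapiens), read by fluorescence, with a stated time of 10 min; on this read-out lower numbers stand for stronger inhibition and higher numbers for weaker inhibition:
Compound 1 `COCCNC(=O)Cn1sc2ccccc2c1=O`: 11800 nM
Compound 2 `O=C(Cn1sc2ccccc2c1=O)NCc1ccccn1`: 15100 nM
Compound 3 `CCOC(=O)Cn1sc2nc(C)cc(C)c2c1=O`: 13600 nM

Compound 2 gives the highest of the three numbers in this assay, but its separation from the others is small: compound 1 sits lower by a 1.3-fold higher number from compound 1 to compound 2 (0.11 log units; within the scatter), and compound 3, which carries a different core, shows a value that differs from that of compound 2 by less than the scatter. On these numbers the three compounds cannot be told apart.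

Compound 4 `O=C(Cn1sc2ccccc2c1=O)Nc1nccs1` keeps the core of compound 2 and changes the amide substituent: 1,3-thiazol-2-yl in place of (pyridin-2-yl)methyl on an amide-type nitrogen. Among the compounds with values here, the only measured step on the amide side, from compound 1 to compound 2, exchanged one amide substituent for another and stayed within the scatter. Within the data shown here, no measured pair exchanges a methylene-linked aryl for an aryl bound directly to the amide-type nitrogen, nor puts a 1,3-thiazol-2-yl group into this position, so the present step has no direct precedent.

Given that every change seen so far has left this assay essentially unmoved, the step from compound 2 to compound 4 is expected to be a 1.1-fold lower number from compound 2 to compound 4 (0.03 log units; within the scatter), with no shift beyond the scatter in either direction. Compound 4 is estimated at 14000 nM, with a plausible range from 5000 nM to 40000 nM.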

Compound 4, half-maximal inhibitory concentration: 9410 nM
Compound 4: the middle estimate sits 1.5-fold (0.17 log units) above what was measured, within the range that was stated.
By their numbers in this assay, from the lowest: compounds 4, 1, 3 and 2 (each within the scatter of the next).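

In this assay, the amide-type nitrogen now carries an aromatic ring bound directly to it, and 1,3-thiazol-2-yl in place of (pyridin-2-yl)methyl gives a 1.6-fold lower number from compound 2 to compound 4 (0.21 log units; within the scatter) on the shared core. This single exchange alters both the ring and its connection to the nitrogen, yet the read-out stays within the scatter. Measured against the open-chain 2-methoxyethyl substituent, the 1,3-thiazol-2-yl group gives a 1.3-fold lower number from compound 1 to compound 4 (0.10 log units; within the scatter) and again stays within the scatter, so the three amide substituents on this core cannot be told apart in this assay. No supporting measurement bears on this result.

The compounds shown do not separate the effect of the ring exchange from that of the linker, which a (1,3-thiazol-2-yl)methyl group on the same nitrogen would address. They also leave open whether a markedly different substituent, such as a chain ending in a primary amine or a carboxylic acid, would move this read-out beyond the scatter, and whether the 1,3-thiazol-2-yl amide would behave alike on the core of compound 3.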